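Aminothiazole series: dimethylamino in place of pyrrolidinyl

The source may report more compounds than this note shows. Statements on the series, on what has been measured and on what is new or still open speak of the compounds shown alone.

Measured so far in a functional assay on HCT-116 cells (Homo sapiens) for cytotoxicity, read by sulforhodamine B assay, with a stated time of 2 days; on this read-out higher numbers stand for weaker inhibition and lower numbers for stronger inhibition:
compound 1 `CN(C)c1ccc(-c2nc3c(s2)C(O)CNC3)cc1`: 1330 nM
compound 2 `OCc1cc(N2CCCC2)ccc1-c1nc2c(s1)C(O)CCC2`: 42 nM
compound 3 `OC1CCCc2nc(-c3ccc(N4CCCC4)cc3)sc21`: 1530 nM

Compound 2 gives the lowest number of the three; the nearest is compound 1, and removal of its hydroxymethyl gives a 36-fold higher number from compound 2 to compound 3 (1.56 log units; beyond the scatter) in this assay. Compound 4 `CN(C)c1ccc(-c2nc3c(s2)C(O)CCC3)c(CO)c1` keeps the hydroxymethyl of compound 2 and changes only the amine: dimethylamino in place of pyrrolidin-1-yl on an aromatic carbon. For the measured compounds named here, no measured step separates these two amines on a shared core; compound 1 carries the dimethylamino but differs from compound 3 in the core as well, and its value tells nothing clean about the amine alone. The step to compound 4 is therefore expected to be small, a 1.9-fold higher number from compound 2 to compound 4 (0.28 log units; within the scatter), with a slightly higher number as the more likely direction. Compound 4 is expected at about 80 nM, within 25 nM to 300 nM.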

Compound 4, half-maximal inhibitory concentration: 60 nM
Estimate against measurement, compound 4: 1.3-fold (0.12 log units) above, within the range that was stated.
By their numbers in this assay, from the lowest: compounds 2 and 4 (each within the scatter of the next); then compounds 1 and 3 (each within the scatter of the next).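

In this assay, for the compounds shown here, the first step between these two amines on a shared core, a 1.4-fold higher number from compound 2 to compound 4 (0.15 log units; within the scatter), lies within the scatter, with the hydroxymethyl kept in both compounds. At this position, para to a large group, dimethylamino and pyrrolidin-1-yl therefore cannot be told apart, and the ring of the pyrrolidin-1-yl is not needed to stay within that scatter of compound 2. No supporting data bear on why the two amines read alike. Open, as far as these compounds go, is whether they also match without the hydroxymethyl, and how a morpholine or a piperidine at this position would read.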